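Swapping the Aryl Group on Compound 3

A few compounds are considered here, and "the series" means these few. Any claim that something is new, unique, unknown or untested is made for them only; others in the source may bear on it.

In a functional assay on DU-145 cells (Homo sapiens) for antiproliferative activity, read by sulforhodamine B assay, with a stated time of 48 h (a higher number here means a weaker inhibitor, a lower number a stronger inhibitor), compound 1 (`Cc1cccc(NS(=O)(=O)c2ccc(N3CCNC3=O)cc2)c1`) gives 580 nM, compound 2 (`O=C1NCCN1c1ccc(S(=O)(=O)Nc2cccc(Br)c2)cc1`) gives 340 nM and compound 3 (`Cc1ccc(C)c(NS(=O)(=O)c2ccc(N3CCNC3=O)cc2)c1`) gives 1610 nM. Compound 3 has the highest number of the three, which makes it the weakest inhibitor so far.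

Compound 4 (`O=C1NCCN1c1ccc(S(=O)(=O)Nc2cccc(Cl)c2)cc1`) has 3-chlorophenyl in place of 2,5-dimethylphenyl on a sulfonamide nitrogen.

The closest measured change is a 4.7-fold higher number from compound 2 to compound 3 (0.68 log units; beyond the scatter), where 2,5-dimethylphenyl replaced 3-bromophenyl. The change to compound 4 runs the opposite way, so a drop of similar size is expected. The step of a 2.8-fold higher number from compound 1 to compound 3 (0.44 log units; beyond the scatter) also points to a higher number with 2,5-dimethylphenyl. Swapping methyl for bromo gave only a 1.7-fold lower number from compound 1 to compound 2 (0.23 log units; within the scatter), which suggests that the exact group at that spot may matter little.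

The expected change in this assay is a fall beyond the scatter, estimated as a 3.8-fold lower number from compound 3 to compound 4 (0.58 log units; beyond the scatter). Compound 4 is estimated at 420 nM, with an expected range of 220 nM to 800 nM.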

Compound 4, half-maximal inhibitory concentration: 230 nM
Compound 4: middle estimate off by 1.8-fold (0.26 log units), on the high side, within the range that was stated.
By their numbers in this assay, from the lowest: compounds 4, 2 and 1 (each within the scatter of the next, the first and the last beyond it); then compound 3.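

In this assay the swap to 3-chlorophenyl on the sulfonamide nitrogen gives a clear gain over the 2,5-dimethylphenyl of compound 3 (a 7.0-fold lower number from compound 3 to compound 4 (0.85 log units; beyond the scatter)), so removing one methyl and exchanging the other for chloro recovers what compound 3 had lost. Chloro and bromo on that aromatic carbon cannot be told apart (a 1.5-fold lower number from compound 2 to compound 4 (0.17 log units; within the scatter)), yet chloro in place of methyl gives a step beyond the scatter (a 2.5-fold lower number from compound 1 to compound 4 (0.40 log units; beyond the scatter)), which the earlier step from methyl to bromo did not (a 1.7-fold lower number from compound 1 to compound 2 (0.23 log units; within the scatter)). Nothing shown here accounts for these differences.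

The compounds shown leave open how a fluoro, methoxy or nitrile group would compare on that same aromatic carbon. They also leave open whether an amine or a carboxylic acid there would be tolerated at all.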